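Naphthyl for benzyl: expected permeability of compound 4

The source may hold more compounds than are shown below. What is called first, only, known or untested is meant among the compounds shown, and "the series" means these compounds.

Compound 1 `COc1cccc(Oc2ccc3c(NCCCNCc4cccc(OC)c4O)ccnc3c2)c1` gives 317 10^-6 cm/s in an ADME assay for permeability, using PAMPA, with a stated time of 30 min, at pH 7.4; a lower number here means that the compound crosses the layer more slowly, a higher number that the compound crosses the layer faster.
Compound 2 `COc1cccc(CNCCCNc2ccnc3cc(Cc4ccc(C#N)cc4)ccc23)c1O` gives 23 10^-6 cm/s in this assay.
Compound 3 `COc1cccc(CNCCCNc2ccnc3cc(Cc4ccccc4)ccc23)c1O` gives 23 10^-6 cm/s in this assay.

Compound 3 shares the lowest number with compound 2, since no change at the digits printed from compound 2 to compound 3 (within the scatter); compound 1 stands far above both, as a 14-fold lower number from compound 1 to compound 3 (1.14 log units; beyond the scatter) shows. Compound 4 `COc1cccc(CNCCCNc2ccnc3cc(-c4cccc5ccccc45)ccc23)c1O` carries naphthalen-1-yl in place of benzyl on an aromatic carbon. Within the data shown here, no measured step exchanges one hydrocarbon group for a larger one at this position: a 14-fold lower number from compound 1 to compound 2 (1.14 log units; beyond the scatter) and a 14-fold lower number from compound 1 to compound 3 (1.14 log units; beyond the scatter) concern an ether-linked group, while no change at the digits printed from compound 2 to compound 3 (within the scatter) shows that a small change on the pendant ring left the number flat. Compound 4 is therefore expected to stay near compound 3, with a 1.3-fold higher number from compound 3 to compound 4 (0.12 log units; within the scatter). The estimate for compound 4 is 30 10^-6 cm/s, expected to fall between 10 10^-6 cm/s and 90 10^-6 cm/s.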

Compound 4, apparent permeability: 237 10^-6 cm/s
Estimate against measurement, compound 4: 7.9-fold (0.90 log units) below; the whole stated range lies below it.
By their numbers in this assay, from the lowest: compounds 2 and 3 (each within the scatter of the next); then compounds 4 and 1 (each within the scatter of the next).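

In this assay, naphthalen-1-yl in place of benzyl (a 10-fold higher number from compound 3 to compound 4 (1.01 log units; beyond the scatter)) and in place of 4-cyanobenzyl (a 10-fold higher number from compound 2 to compound 4 (1.01 log units; beyond the scatter)) shows that a group without an ether link can reach a high number at this position. Set against 3-methoxyphenoxy (a 1.3-fold lower number from compound 1 to compound 4 (0.13 log units; within the scatter)), naphthalen-1-yl cannot be told apart from it, so the ether link is not needed for a high reading among these compounds. Nothing measured here explains the jump. Still open, from the compounds shown here alone, is whether a directly attached phenyl or naphthalen-2-yl on this carbon would read with compound 4 or with compound 3, which would separate the added ring from the loss of the benzyl link.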